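The source may hold more compounds than are shown below. What is called first, only, known or untested is meant among the compounds shown, and "the series" means these compounds.

Working notes on the series. Three compounds have numbers in a functional assay on SW-620 cells (Homo sapiens) for inhibition, read by MTT assay, with a stated time of 48 h; on this read-out lower numbers stand for stronger inhibition and higher numbers for weaker inhibition. Compound 1 `Cc1ccc(NC(=S)NC(=O)c2ccc(OCc3ccccc3)cc2)cc1-c1nc2ccccc2[nH]1` gives 67100 nM, compound 2 `Cc1ccc(NC(=S)NC(=O)c2ccc(OCc3ccc(C(F)(F)F)cc3)cc2)cc1-c1nc2ccccc2[nH]1` gives 72400 nM, and compound 3 `Cc1ccc(NC(=O)NC(=O)c2ccc(OCc3ccccc3F)cc2)cc1-c1nc2ccccc2[nH]1` gives 4110 nM. Compound 3 stands lowest of the three: its gap to compound 1 is beyond the scatter, and its gap to compound 2 is wider still. For the measured compounds named here, compounds 1 and 2, both with a thiourea link, sit close together; the one fully described single-point step, a 1.1-fold higher number from compound 1 to compound 2 (0.03 log units; within the scatter), lies within the scatter.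

Compound 4 `Cc1ccc(NC(=O)NC(=O)c2ccc(OCc3ccccc3Cl)cc2)cc1-c1nc2ccccc2[nH]1` has not yet been measured. It differs from compound 3 in one place: chloro in place of fluoro on an aromatic carbon. Going by the values given here, no measured step exchanges one halogen for another, and the only single-point step available, a 1.1-fold higher number from compound 1 to compound 2 (0.03 log units; within the scatter), concerns a different substituent on a different aromatic carbon; it bears on the present change only in showing that one substituent swap on that part of the molecule gave no movement in this assay . The urea link that sets compound 3 apart from compounds 1 and 2 is kept in compound 4.

On that basis compound 4 is expected to give a step of a 1.1-fold lower number from compound 3 to compound 4 (0.03 log units; within the scatter), that is, nothing beyond the scatter. The estimate for compound 4 in this assay is 3800 nM, with a range from 1500 nM to 9500 nM.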

Compound 4, half-maximal inhibitory concentration: 35700 nM
Beside the measured number, compound 4's estimate is 9.4-fold (0.97 log units) below it, outside the stated range (above it).
By their numbers in this assay, from the lowest: compound 3; then compounds 4, 1 and 2 (each within the scatter of the next, the first and the last beyond it).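

In this assay, replacing 2-fluorobenzyl with 2-chlorobenzyl gives an 8.7-fold higher number from compound 3 to compound 4 (0.94 log units; beyond the scatter), so a single halogen exchange on this aromatic carbon, ortho to a large group, moves the number beyond the scatter, although the entering and leaving groups match in heavy-atom, hydrogen-bond donor and hydrogen-bond acceptor counts. For the compounds shown here, the only earlier single-place step, a 1.1-fold higher number from compound 1 to compound 2 (0.03 log units; within the scatter), involves trifluoromethyl on a different aromatic carbon of the thiourea pair and showed no movement beyond the scatter; the new step is the first to show that a substituent change on this benzyl group can register in this assay, and that keeping the urea link does not by itself preserve the number of compound 3. No measured information on the reason for this step is available here.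

Going by these compounds, how bromo, methyl or methoxy on this same carbon would read with the urea link remains open. Also open, on these data alone, is whether the exchange of fluoro for chloro would give a comparable step with the thiourea link or on another carbon of the same aromatic ring.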